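The compounds below may be only part of what the source reports. "The series", "measured", "known", "first", "only" and "open" are said of these compounds alone.

Compound 1 `Cc1ccc(C(=O)OC2(C(=O)Nc3ccc([N+](=O)[O-])cc3)CCCCC2)cc1` gives 32 nM in an ADME assay on WI-38 cells (Homo sapiens) for inhibition, read by MTT assay, with a stated time of 72 h; on this read-out lower numbers stand for stronger inhibition and higher numbers for weaker inhibition.
Compound 2 `COc1ccc(C(=O)OC2(C(=O)Nc3ccc([N+](=O)[O-])cc3)CCCCC2)cc1` gives 40 nM in this assay.
Compound 3 `Cc1ccccc1C(=O)OC1(C(=O)Nc2ccc([N+](=O)[O-])cc2)CCCCC1` gives 352 nM in this assay.

Among these three, compound 3 has the highest number, that is the weakest inhibition: the step of an 11-fold higher number from compound 1 to compound 3 (1.04 log units; beyond the scatter) and the step of an 8.8-fold higher number from compound 2 to compound 3 (0.94 log units; beyond the scatter) both lie beyond the scatter. Compound 4 `O=C(OC1(C(=O)Nc2ccc([N+](=O)[O-])cc2)CCCCC1)c1ccccc1I` differs from compound 3 by iodo in place of methyl on an aromatic carbon. Within the data shown here, no measured step swaps one small group for another at this place. Among the measured compounds shown here, the only comparable swap, a 1.3-fold higher number from compound 1 to compound 2 (0.10 log units; within the scatter), sits at a different place and stayed within the scatter, while the two large steps concern where the group sits, which compound 4 keeps. Compound 4 is therefore expected to show a 1.0-fold lower number from compound 3 to compound 4 (0.00 log units; within the scatter), no step beyond the scatter. The estimate for compound 4 in this assay is 350 nM, within 120 nM to 1000 nM.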

Compound 4, half-maximal inhibitory concentration: 396 nM
Compound 4: the middle estimate sits 1.1-fold (0.05 log units) below what was measured, within the range that was stated.
By their numbers in this assay, from the lowest: compounds 1 and 2 (each within the scatter of the next); then compounds 3 and 4 (each within the scatter of the next).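

In this assay, iodo and methyl at this place on the ring cannot be told apart (a 1.1-fold higher number from compound 3 to compound 4 (0.05 log units; within the scatter)). Compound 4 therefore joins compound 3 on the weaker side, as the two further steps show (a 9.9-fold higher number from compound 2 to compound 4 (1.00 log units; beyond the scatter); a 12-fold higher number from compound 1 to compound 4 (1.09 log units; beyond the scatter)). So the higher number of compound 3 is not special to methyl, though two groups are a small sample, and no measurement shown explains the result. From the compounds shown here alone, what an amine or a carboxylic acid would give at this place stays open.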